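Three Side Chains on One Lactam Core

This account rests on a few compounds, and the source may have more. Where it says the series, first, only, none or still open, it means among the compounds named here.

Compound 1 `CCCCOc1ccc(C2CNC(=O)C2)cc1OC` and compound 2 `COc1ccc(C2CNC(=O)C2)cc1OCC(C)C` share one core and differ only in the saturated chain bound to an oxygen on the aromatic ring. In an assay on isolated protein for inhibition of phosphodiesterase 1 (Bos taurus), read by cGMP accumulation, in the presence of a further agent that is not named here (on this read-out higher numbers stand for weaker inhibition and lower numbers for stronger inhibition), compound 1 gives > 1000000 nM, which is a limit of the assay rather than a number. In this assay compound 2 likewise gives > 1000000 nM, again a limit and not a measured value. Where compound 2 stands is therefore known only as far as the limit of > 1000000 nM in this assay, at which 2 of the 2 values shown sit, and no order between the two measured compounds can be read from these values.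

Compound 3 `CCOC(=O)CCCOc1cc(C2CNC(=O)C2)ccc1OC` has not yet been measured. It differs from compound 2 in one place: 2-(ethoxycarbonyl)ethyl in place of isopropyl on a saturated chain carbon bound to an oxygen on an aromatic ring. Going by the values given here, because both measured compounds sit at the limit of > 1000000 nM in this assay, at which 2 of the 2 values shown sit, there is no measured step between related compounds to build on. In this assay the step expected is a number no higher from compound 2 to compound 3 (the limit leaves the size open), nothing beyond the usual scatter. Compound 3 is accordingly estimated at 1000000 nM in this assay, with a plausible range from 200000 nM to 5000000 nM, and a report of only a limit is expected to remain the most probable outcome.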

Compound 3, half-maximal inhibitory concentration: > 1000000 nM
Compound 3: only a limit was reported (the forecaster's own chance of this, stated with the estimate: 80%); the middle value lies on the limit itself.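

No step can be read from compound 2 to compound 3, since each is reported only as a limit in this assay and compound 1 is no different: the limit of > 1000000 nM in this assay, at which 3 of the 3 values shown sit. The compounds shown leave open whether any of these side chains on the shared core gives measurable inhibition, and how far each compound lies beyond that limit.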